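The source may hold more compounds than are shown below. What is called first, only, known or untested is meant among the compounds shown, and "the series" means these compounds.

Compound 2 `COC(=O)/C=C/[C@H]1OCCC[C@@H]1O[Si](C)(C)C(C)(C)C` stands level with compound 1 `COC(=O)/C=C/C[C@H]1OCCC[C@@H]1O[Si](C)(C)C(C)(C)C` in a functional assay on HL-60 cells (Homo sapiens); on this read-out lower numbers stand for stronger inhibition of growth and higher numbers for weaker inhibition of growth: compound 2 gives 22000 nM, and compound 1 gives 22000 nM. Within the data shown here, the step of no change at the digits printed from compound 1 to compound 2 (within the scatter) is the only measured step, and it alters the chain that carries the ester while keeping the ester itself. The next compound, compound 3 `CC(C)(C)[Si](C)(C)O[C@H]1CCCO[C@@H]1/C=C/CO`, is still to be measured in this assay. It differs from compound 2 in one place: hydroxymethyl in place of methoxycarbonyl on a double-bonded chain carbon bound to a double-bonded chain carbon. Among the measured compounds shown here, no measured step changes the methoxycarbonyl group, so the one known step, from compound 1 to compound 2, bears on the new step only loosely, in that this chain has been altered once before without moving the number in this assay. On that basis the expected step is a 1.4-fold higher number from compound 2 to compound 3 (0.13 log units; within the scatter), that is, no movement beyond the scatter, with weaker inhibition the more likely side should the number move. Compound 3 is therefore estimated to give 30000 nM in this assay, within a range from 10000 nM to 100000 nM.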

Compound 3, concentration for 50% growth inhibition: 31000 nM
Estimate against measurement, compound 3: 1.0-fold (0.01 log units) below; measured number inside the range.
By their numbers in this assay, from the lowest: compounds 1, 2 and 3 (each within the scatter of the next).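

In this assay, among these compounds, hydroxymethyl in place of methoxycarbonyl on a double-bonded chain carbon bound to a double-bonded chain carbon gives a 1.4-fold higher number from compound 2 to compound 3 (0.15 log units; within the scatter), the first measured change to the ester group itself, and it stays within the scatter. The methoxycarbonyl group is therefore not needed to hold the number at this level in this assay, and the earlier step, which kept the ester, could not show this. The wider replacement, 3-hydroxyprop-1-en-1-yl in place of 3-(methoxycarbonyl)prop-2-en-1-yl on a saturated ring carbon, gives a 1.4-fold higher number from compound 1 to compound 3 (0.15 log units; within the scatter), so this larger difference also stays within the scatter, and no available evidence bears on the result.

The compounds shown leave open whether any change at this place can move the number beyond the scatter, as all three remain within the scatter of one another. An amine or a carboxylic acid in place of the hydroxymethyl, or a longer chain ending in a hydroxyl, would test whether the number in this assay responds to this position at all.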